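Adding a Second Fluoro to the Core of Compound 2

The compounds below may be only part of what the source reports. "The series", "measured", "known", "first", "only" and "open" are said of these compounds alone.

Of the compounds shown here, three sharing one core have been measured in a functional assay for agonist activity at P2Y purinoceptor 2 (Homo sapiens), read by FLIPR; on this read-out higher numbers stand for an effect only at larger amounts of compound and lower numbers for an effect already at smaller amounts. Compound 1 `O=c1c2ccccc2ccn1[C@@H]1O[C@H](COP(=O)(O)OP(=O)(O)OP(=O)(O)O)[C@@H](O)[C@H]1O` gives 31 nM. Compound 2 `O=c1c2ccc(F)cc2ccn1[C@@H]1O[C@H](COP(=O)(O)OP(=O)(O)OP(=O)(O)O)[C@@H](O)[C@H]1O` gives 77 nM, and compound 3 `N#Cc1ccc2c(=O)n([C@@H]3O[C@H](COP(=O)(O)OP(=O)(O)OP(=O)(O)O)[C@@H](O)[C@H]3O)ccc2c1` gives 88 nM. Compound 2 therefore stands second highest of the three: its number sits within the scatter of compound 3, the gap being a 1.1-fold higher number from compound 2 to compound 3 (0.06 log units; within the scatter), while compound 1 lies clearly lower, since the step is a 2.5-fold higher number from compound 1 to compound 2 (0.40 log units; beyond the scatter).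

Compound 4 `O=c1c2cc(F)c(F)cc2ccn1[C@@H]1O[C@H](COP(=O)(O)OP(=O)(O)OP(=O)(O)O)[C@@H](O)[C@H]1O` differs from compound 2 in one place: fluoro in place of hydrogen on an aromatic carbon. Within the data shown here, two measured steps bear on a change of this kind on this core. Putting fluoro onto compound 1 gave a 2.5-fold higher number from compound 1 to compound 2 (0.40 log units; beyond the scatter), and putting cyano onto compound 1 gave a 2.8-fold higher number from compound 1 to compound 3 (0.45 log units; beyond the scatter). Both moved the number up by a modest amount. Placing a further fluoro onto compound 2 is therefore expected to raise the number again by a modest amount, though it could also stay within the scatter. Compound 4 is estimated at 130 nM, in a range from 50 nM to 350 nM, which means an expected step of a 1.7-fold higher number from compound 2 to compound 4 (0.23 log units; within the scatter) in this assay.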

Compound 4, half-maximal effective concentration: 16 nM
Estimate against measurement, compound 4: 8.1-fold (0.91 log units) above; measured number outside the range, below it.
By their numbers in this assay, from the lowest: compounds 4 and 1 (each within the scatter of the next); then compounds 2 and 3 (each within the scatter of the next).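

The second fluoro, placed on an aromatic carbon ortho to the fluoro group already on the ring, gives a 4.8-fold lower number from compound 2 to compound 4 (0.68 log units; beyond the scatter) in this assay. The earlier step on this core, a 2.5-fold higher number from compound 1 to compound 2 (0.40 log units; beyond the scatter), involved the same kind of change but went the other way, so putting fluoro in place of hydrogen has no single direction here: the outcome depends on where the fluoro goes, on what is already on the ring, or on both. Nothing available here explains this reversal.

Going by these compounds, it remains open whether the lower number comes from this position alone or needs the neighbouring fluoro group to be present. A chloro, methoxy or amine group at the same place could also move the number differently, and the compounds shown do not settle this.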